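The source may hold more compounds than are shown below. What is called first, only, known or untested is meant among the compounds shown, and "the series" means these compounds.

The three measured compounds share one core. In a functional assay on HeLa cells (Homo sapiens) for inhibition, read by MTT assay, with a stated time of 48 h (on this read-out higher numbers stand for weaker inhibition and lower numbers for stronger inhibition), compound 1 `Cn1cc(NC(=O)c2cccc(NS(=O)(=O)c3ccccc3)c2)cn1` gives 78500 nM. In this assay compound 2 `O=C(Nc1cnn(-c2ccccc2)c1)c1cccc(NS(=O)(=O)c2ccccc2)c1` gives 15300 nM, and compound 3 `COc1ccc(-n2cc(NC(=O)c3cccc(NS(=O)(=O)c4ccccc4)c3)cn2)cc1` gives 42200 nM. Compound 2 stands lowest of the three numbers: the step of a 5.1-fold lower number from compound 1 to compound 2 (0.71 log units; beyond the scatter) and the step of a 2.8-fold higher number from compound 2 to compound 3 (0.44 log units; beyond the scatter) both lie beyond the scatter, while the step of a 1.9-fold lower number from compound 1 to compound 3 (0.27 log units; within the scatter) stays within it.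

Compound 4 `O=C(Nc1cnn(-c2ccccc2)c1)c1cccc(NS(=O)(=O)c2ccc(Cl)cc2)c1` differs from compound 2 by chloro in place of hydrogen on an aromatic carbon. Within the data shown here, no measured step touches this ring. Among the measured compounds shown here, the only measured pair in which a hydrogen on an aromatic carbon is replaced is a 2.8-fold higher number from compound 2 to compound 3 (0.44 log units; beyond the scatter), a modest rise on a different ring of the molecule, and the two steps from compound 1 concern a change on an aromatic nitrogen rather than on a carbon. For the measured compounds named here, there is thus no measured step that speaks directly to a chlorine on the phenylsulfonyl part. On that slender basis the step of a 1.0-fold lower number from compound 2 to compound 4 (0.01 log units; within the scatter) is expected to be small, in either direction, and most likely not beyond the scatter. Compound 4 is accordingly estimated at 15000 nM, with a range from 5000 nM to 45000 nM.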

Compound 4, half-maximal inhibitory concentration: 5410 nM
Compound 4: middle estimate off by 2.8-fold (0.44 log units), on the high side; measured number inside the range.
By their numbers in this assay, from the lowest: compound 4; then compound 2; then compounds 3 and 1 (each within the scatter of the next).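

In this assay, among these compounds, the step of a 2.8-fold lower number from compound 2 to compound 4 (0.45 log units; beyond the scatter) is the first measured change on the phenylsulfonyl part, and it shows that this ring responds to substitution: a single chloro on an aromatic carbon, para to a large group, gives stronger inhibition by more than the scatter. The only earlier replacement of a hydrogen on an aromatic carbon, a 2.8-fold higher number from compound 2 to compound 3 (0.44 log units; beyond the scatter), put methoxy on the other phenyl ring and went the opposite way, so among the compounds shown, adding a substituent to the compound 2 scaffold does not move the number in one fixed direction, although group and ring both differ between these two steps. Nothing measured here accounts for the effect of the chloro group on this ring.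

The compounds shown leave open whether the change belongs to chloro itself or would also appear with fluoro, bromo, methyl, an amine or a carboxylic acid at the same place. They also leave open whether chloro would act the same way elsewhere on this ring, or on the shared core carrying the methyl group of compound 1.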